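The source may report more compounds than this note shows. Statements on the series, on what has been measured and on what is new or still open speak of the compounds shown alone.

Of the compounds shown here, three sharing one core have been measured in an assay on isolated protein with malate dehydrogenase, mitochondrial (Sus scrofa) as the target; on this read-out lower numbers stand for stronger inhibition and higher numbers for weaker inhibition. Compound 1 `CN(C)c1ccc2c(O)c(C(=O)O)cnc2c1` gives 479000 nM, compound 2 `O=C(O)c1cnc2cc(O)ccc2c1O` gives 490000 nM, and compound 3 `CC(=O)c1ccc2c(O)c(C(=O)O)cnc2c1` gives 912000 nM. Compound 3 holds the highest of the three numbers, yet its steps to both neighbours, a 1.9-fold higher number from compound 1 to compound 3 (0.28 log units; within the scatter) and a 1.9-fold higher number from compound 2 to compound 3 (0.27 log units; within the scatter), stay within the scatter, as does a 1.0-fold higher number from compound 1 to compound 2 (0.01 log units; within the scatter), so no order among the three can be read.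

Compound 4 `NC(=O)c1ccc2c(O)c(C(=O)O)cnc2c1` follows from compound 3 by the change (amino in place of methyl on a carbonyl carbon). Within the data shown here, no measured step touches the carbonyl carbon; the three steps so far all swap groups on an aromatic carbon, and each of them lies within the scatter. On that basis a step beyond the scatter is not expected in this assay for compound 4, in either direction. Compound 4 is therefore estimated at 800000 nM, with a range from 300000 nM to 2000000 nM, a step of a 1.1-fold lower number from compound 3 to compound 4 (0.06 log units; within the scatter) expected from compound 3. Given that all numbers so far sit near the upper edge of the usable range, a limit rather than a number is a real possibility.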

Compound 4, half-maximal inhibitory concentration: 741000 nM
Compound 4: middle estimate off by 1.1-fold (0.03 log units), on the high side; measured number inside the range.
By their numbers in this assay, from the lowest: compounds 1, 2, 4 and 3 (each within the scatter of the next).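

Among these compounds, changing methyl to amino on the carbonyl carbon, which turns acetyl into carbamoyl and brings in one hydrogen-bond donor, is the first change at this carbonyl carbon, and in this assay it stays within the scatter (a 1.2-fold lower number from compound 3 to compound 4 (0.09 log units; within the scatter)). Carbamoyl also stays within the scatter of the hydroxy and dimethylamino groups on the aromatic carbon (a 1.5-fold higher number from compound 2 to compound 4 (0.18 log units; within the scatter); a 1.5-fold higher number from compound 1 to compound 4 (0.19 log units; within the scatter)), so the four groups now shown there cannot be ordered. No evidence at hand bears on these results.

Still open, from the compounds shown here alone, is whether any other group on that aromatic carbon, such as a sulfonamide, a morpholine or a longer chain on the amide nitrogen, gives a step beyond the scatter. Also open, going by these compounds, is whether a change elsewhere on the shared core, such as a tetrazole in place of the carboxylic acid, moves the number further.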